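The source may hold more compounds than are shown below. What is called first, only, known or untested is meant among the compounds shown, and "the series" means these compounds.

Compound 1 `CCCCNc1nc(SC)nc2ncccc12` carries a butyl group on the ring nitrogen, and in a functional assay (Nicotiana tabacum) (a higher number here means a weaker inhibitor, a lower number a stronger inhibitor), compound 1 gives 270 nM. Within the data shown here, compound 2 `CSc1nc(NC2CCC2)c2cccnc2n1` replaces that chain with a cyclobutyl ring; in this assay compound 2 gives 720 nM, the higher of the two numbers measured so far, and the step of a 2.7-fold higher number from compound 1 to compound 2 (0.43 log units; beyond the scatter) is a modest one, beyond the scatter. Compound 3 `CCC(C)Nc1nc(SC)nc2ncccc12` has not yet been measured. The change from compound 2 to it is sec-butyl in place of cyclobutyl on a nitrogen on an aromatic ring. Among the measured compounds shown here, only one measured step bears on this: the step of a 2.7-fold higher number from compound 1 to compound 2 (0.43 log units; beyond the scatter), which shows that the closed cyclobutyl ring gave a weaker inhibitor than the open butyl chain. The sec-butyl group of compound 3 is again an open chain of the same count of carbons but branched, so the step is expected to run back toward compound 1, though not necessarily all the way, since the branched chain is not the straight one. For compound 3 the expected step is a 1.8-fold lower number from compound 2 to compound 3 (0.26 log units; within the scatter), a moderate fall in the number. Compound 3 is therefore estimated at 400 nM in this assay, with a range from 150 nM to 1100 nM.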

Compound 3, half-maximal inhibitory concentration: 860 nM
Compound 3: the middle estimate sits 2.2-fold (0.33 log units) below what was measured, and the stated range covers the measured number.
By their numbers in this assay, from the lowest: compound 1; then compounds 2 and 3 (each within the scatter of the next).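

In this assay the step of a 1.2-fold higher number from compound 2 to compound 3 (0.08 log units; within the scatter) places the open sec-butyl group within the scatter of the closed cyclobutyl ring, so on this nitrogen, an open chain in place of the ring does not by itself bring back the number of compound 1. The step of a 3.2-fold higher number from compound 1 to compound 3 (0.50 log units; beyond the scatter) is beyond the scatter and sets the straight butyl chain of compound 1 apart from the branched sec-butyl group as well, so the difference first seen between compound 1 and compound 2 can no longer be read simply as one between a ring and an open chain. Nothing measured here accounts for why the straight chain stands apart from the other two groups.

The three compounds leave open whether a longer chain such as pentyl would continue the trend set by butyl, or whether a shorter propyl chain or a larger cyclopentyl ring would fall with the sec-butyl and cyclobutyl groups. They also leave open how a hydroxyl or an amine at the end of the butyl chain would read in this assay, and whether the methylthio group elsewhere on the shared core matters to any of these steps.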